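Trimming a methoxy from a nitro enaminone series

This account rests on a few compounds, and the source may have more. Where it says the series, first, only, none or still open, it means among the compounds named here.

Measured compounds:
Compound 1, `COc1ccc(C(=O)/C=C\Nc2ccc(-c3nc4cc(OC)c(OC)c(OC)c4s3)cc2)cc1[N+](=O)[O-]`, 15900 nM
Compound 2, `COc1cc(C(=O)/C=C\Nc2ccc(-c3nc4cc(OC)c(OC)c(OC)c4s3)cc2)cc([N+](=O)[O-])c1OC`, 15800 nM

Both were tested in a functional assay on MIA PaCa-2 cells (Homo sapiens) for antiproliferative activity, read by sulforhodamine B assay, with a stated time of 48 h; on this read-out lower numbers stand for stronger inhibition and higher numbers for weaker inhibition. Compound 2 carries the lowest of the two numbers, but its nearest neighbour, compound 1, sits within the scatter, so the two cannot be told apart. Among the compounds with values here, the only measured step, a 1.0-fold lower number from compound 1 to compound 2 (0.00 log units; within the scatter), concerns methoxy in place of hydrogen on an aromatic carbon of the ketone-bearing ring and was flat.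

Compound 3, `COc1cc(OC)c2sc(-c3ccc(N/C=C\C(=O)c4cc(OC)c(OC)c([N+](=O)[O-])c4)cc3)nc2c1`, differs from compound 2 by hydrogen in place of methoxy on an aromatic carbon. Within the data shown here, the change sits on the fused ring system of the shared core, ortho to two methoxy groups, meta to a fused ring and para to a fused ring, a position on which none of the measured steps gives information. Among the measured compounds shown here, with no directly bearing step and a flat precedent, the author expects no move beyond the scatter, allowing a somewhat higher number, as a 1.3-fold higher number from compound 2 to compound 3 (0.10 log units; within the scatter). Compound 3 is therefore estimated at 20000 nM, within 8000 nM to 50000 nM.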

Compound 3, half-maximal inhibitory concentration: 12700 nM
Estimate against measurement, compound 3: 1.6-fold (0.20 log units) above; the range from low to high includes it.
By their numbers in this assay, from the lowest: compounds 3, 2 and 1 (each within the scatter of the next).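

In this assay, within the data shown here, hydrogen in place of methoxy on an aromatic carbon of the shared core, ortho to two methoxy groups, gives a 1.2-fold lower number from compound 2 to compound 3 (0.09 log units; within the scatter) and thus provides the first measured step at this position of the fused ring system. This methoxy can therefore go without a change that can be told from the scatter, just as adding a methoxy on the ketone-bearing ring gave a 1.0-fold lower number from compound 1 to compound 2 (0.00 log units; within the scatter) and left the number within the scatter, so none of the three compounds can be ranked above another. No measurement is at hand that would explain this flat result.

The compounds shown leave open whether a group other than methoxy or hydrogen at this position, such as an amine, a hydroxyl or a carboxylic acid, would move the number beyond the scatter. They also leave open whether the two methoxy groups that remain on the fused ring system could go as well, and whether replacing the nitro group with a nitrile or an amine would change the number.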